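Swapping a Difluorophenyl for a Methoxyphenyl: What to Expect

This account rests on a few compounds, and the source may have more. Where it says the series, first, only, none or still open, it means among the compounds named here.

Compound 1 `CCOC(=O)C1=Cc2ccccc2OC1(OCc1cc(-c2ccc(F)cc2F)no1)C(F)(F)F`: in a functional assay on HeLa cells (Homo sapiens) for inhibition, read by MTT assay, with a stated time of 24 h (a lower number here means a stronger inhibitor, a higher number a weaker inhibitor), compound 1 gives > 150000 nM, a limit of the assay.
Compound 2 `CCOC(=O)C1=Cc2ccccc2OC1(OCc1cn(CC(=O)NC2CCCCC2)nn1)C(F)(F)F`: in this assay compound 2 gives 11400 nM.
Compound 3 `CCOC(=O)C1=Cc2ccccc2OC1(OCc1cn(-c2ccc(F)c([N+](=O)[O-])c2)nn1)C(F)(F)F`: in this assay compound 3 gives 15600 nM.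

Compound 1 stands at the limit of > 150000 nM in this assay, at which 1 of the 3 values shown sits, so only a limit is known for it. Compound 4 `CCOC(=O)C1=Cc2ccccc2OC1(OCc1cc(-c2ccc(OC)cc2)no1)C(F)(F)F` differs from compound 1 by 4-methoxyphenyl in place of 2,4-difluorophenyl on an aromatic carbon. Among the measured compounds shown here, the single measured step, a 1.4-fold higher number from compound 2 to compound 3 (0.14 log units; within the scatter), changes a group on an aromatic nitrogen of a different five-membered ring, so it offers no guide to the size or direction of this change. The expectation for compound 4 therefore rests on the limit of compound 1 alone. Compound 4 is expected to give 150000 nM, within 30000 nM to 500000 nM, quite possibly again only a limit. That estimate means a number no higher from compound 1 to compound 4 (the limit leaves the size open), which is expected to stay within the scatter.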

Compound 4, half-maximal inhibitory concentration: > 150000 nM
Compound 4: no number, only a limit (the forecaster's own chance of this, stated with the estimate: 60%); the middle value lies on the limit itself.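

Compound 1 and compound 4 each give only a limit in this assay, not a number, so the step between them cannot be read: the limit of > 150000 nM in this assay, at which 2 of the 4 values shown sit.

Left open is whether 4-methoxyphenyl in place of 2,4-difluorophenyl changes inhibition at all.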